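Swapping a ring amine for an open chain on a quinolone core

The source may report more compounds than this note shows. Statements on the series, on what has been measured and on what is new or still open speak of the compounds shown alone.

Compound 1, `CN[C@@H]1CCN(c2cc3c(cc2F)c(=O)c(C(=O)O)cn3Cc2ccc(-c3ccccc3)cc2)C1`, in an assay on isolated protein for inhibition of DNA topoisomerase 1 (Homo sapiens), with a stated time of 15 min (a higher number here means a weaker inhibitor, a lower number a stronger inhibitor), gives 34800 nM.
Compound 2, `O=C(O)c1cn(Cc2ccc(-n3cccn3)cc2)c2cc(NC[C@@H]3CCNC3)c(F)cc2c1=O`, in this assay gives 200000 nM.

Of the two measured compounds, compound 1 has the lower number and so is the stronger inhibitor; the gap to compound 2 lies beyond the usual scatter of this measurement. Compound 3, `NCCNc1cc2c(cc1F)c(=O)c(C(=O)O)cn2Cc1ccc(-c2ccccc2)cc1`, is the unmeasured partner of compound 1. It keeps the shared core of compound 1 and differs in one place: (2-aminoethyl)amino in place of 3-(methylamino)pyrrolidin-1-yl on an aromatic carbon. A ring bearing a basic nitrogen is thus exchanged for a short open chain that carries the same two nitrogens without a ring. Among the measured compounds shown here, no measured pair shows the effect of this exact change, and compound 2 differs from compound 1 in several places at once, so it gives no clean guide. With nothing else to go on, the step from compound 1 to compound 3 is expected to be small and to sit near the scatter, if anything toward a weaker inhibitor, as a 1.7-fold higher number from compound 1 to compound 3 (0.24 log units; within the scatter). The estimate for compound 3 in this assay is 60000 nM, with a likely range from 15000 nM to 200000 nM.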

Compound 3, half-maximal inhibitory concentration: 72800 nM
For compound 3 the middle estimate is 1.2-fold (0.08 log units) below the measured one; the range from low to high includes it.
By their numbers in this assay, from the lowest: compound 1; then compound 3; then compound 2.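

Among the compounds shown here, this pair gives the first clean reading of a change at this position, the aromatic carbon ortho to a fluoro group. In this assay, putting (2-aminoethyl)amino in place of 3-(methylamino)pyrrolidin-1-yl gives a 2.1-fold higher number from compound 1 to compound 3 (0.32 log units; beyond the scatter), a modest step toward a weaker inhibitor that removes the ring and the defined stereocentre together. So with this core and this benzyl-type substituent held constant, the ring-bearing group holds the advantage, but the open chain still gives a measurable value, and nothing measured here explains the difference.

The swap changes the ring, the stereocentre and the chain at once, so the compounds shown cannot say which of these accounts for the step. A longer chain such as (3-aminopropyl)amino, or a six-membered ring amine such as piperazin-1-yl, placed on the same aromatic carbon would help show whether the ring itself matters or only the length and shape of the group carrying the two nitrogens.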